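Coumarin Amides: Methyl Substituent on the Aryl Ring

This account rests on a few compounds, and the source may have more. Where it says the series, first, only, none or still open, it means among the compounds named here.

Measured compounds:
Compound 1, `O=C(NC1CCCCC1)c1cc2ccccc2oc1=O`: 500 nM
Compound 2, `O=C(Nc1ccccc1)c1cc2ccccc2oc1=O`: 760 nM
Compound 3, `O=C(Nc1cccc(C(F)(F)F)c1)c1cc2ccccc2oc1=O`: 250 nM

All three share one core and differ only in the group on the amide-type nitrogen. In an in vitro assay on BTI-TN-5B1-4 cells for inhibition of Amine oxidase [flavin-containing] B (Homo sapiens), read by fluorescence (on this read-out lower numbers stand for stronger inhibition and higher numbers for weaker inhibition), compound 2 gives the largest of the three numbers, but a 1.5-fold higher number from compound 1 to compound 2 (0.18 log units; within the scatter) leaves compounds 1 and 2 indistinguishable, while a 3.0-fold lower number from compound 2 to compound 3 (0.48 log units; beyond the scatter) is a real, modest gain.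

Compound 4, `Cc1ccc(NC(=O)c2cc3ccccc3oc2=O)cc1`, is not yet measured. It differs from compound 2 by methyl in place of hydrogen on an aromatic carbon.

The step that bears on it most is a 3.0-fold lower number from compound 2 to compound 3 (0.48 log units; beyond the scatter), a substituent entering the same ring in the same kind of place, although that group and position are not identical to those in compound 4. On that basis a small step downward in this assay is expected for compound 4, likely not beyond the scatter, giving an estimated 1.5-fold lower number from compound 2 to compound 4 (0.18 log units; within the scatter). Compound 4 is therefore estimated at 500 nM, with a range from 200 nM to 1200 nM.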

Compound 4, half-maximal inhibitory concentration: 710 nM
The estimate for compound 4 lay 1.4-fold (0.15 log units) below the measured number; the measured number falls inside the stated range.
By their numbers in this assay, from the lowest: compounds 3, 1, 4 and 2 (each within the scatter of the next, the first and the last beyond it).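

Putting methyl on an aromatic carbon para to a large group gives a 1.1-fold lower number from compound 2 to compound 4 (0.03 log units; within the scatter) in this assay, so no effect of this change can be claimed. Adding a group to this ring is therefore not enough on its own to move the number, at least when that group is a single methyl at this position. Replacing cyclohexyl with 4-methylphenyl gives a 1.4-fold higher number from compound 1 to compound 4 (0.15 log units; within the scatter), so this ring, like plain phenyl, cannot be told apart from cyclohexyl in this assay.

From the compounds shown here alone, whether trifluoromethyl, a methoxy group or an amine at this same place would move the number remains open, as does how methyl behaves on the other carbons of this ring. Nothing measured here accounts for this result.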